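A few compounds are considered here, and "the series" means these few. Any claim that something is new, unique, unknown or untested is made for them only; others in the source may bear on it.

The study concerns three anilides built on the shared core of compound 1 `CCC(C)C(C(=O)Nc1ccc(C(C)=O)cc1)N(C(=O)c1ccccc1)S(=O)(=O)c1ccc(C)cc1`. In a functional assay for inhibition, read by spectrophotometry, with a stated time of 20 min, tested at 3 mg/mL (on this read-out higher numbers stand for a stronger effect at the one concentration tested and lower numbers for a weaker effect), compound 1 gives 33.4%. Compound 2 `CC(=O)c1ccc(NC(=O)C(CC(C)C)N(C(=O)c2ccccc2)S(=O)(=O)c2ccccc2)cc1` is the second measured member, and in this assay compound 2 gives 40.7%. Within the data shown here, of the two numbers recorded so far, the one for compound 2 stands highest, yet its distance from compound 1 lies within the usual scatter of repeated measurements, so the two values show no real separation between these compounds.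

Compound 3 `CCC(C)C(C(=O)Nc1ccc(C(C)=O)cc1)N(C(=O)c1ccccc1)S(=O)(=O)c1ccccc1` has not yet been tested in this assay. It shares all its atoms with compound 2, joined differently: sec-butyl in place of isobutyl on a saturated chain carbon bound to an amide-type nitrogen and a carbonyl carbon. No comparison between two measured compounds isolates this change, so there is nothing to anchor a step for it. With compound 1 at 33.4% and compound 2 at 40.7% sitting close together, the expected step of a number 3.7 percentage points lower from compound 2 to compound 3 (within the scatter) is small, of uncertain direction, and not beyond the scatter. Compound 3 is estimated at 37% in this assay, with a range from 24% to 50%.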

Compound 3, a percentage reported as inhibition, at one concentration (the size of the read-out at that concentration, not a potency): 14.3%
Compound 3: the middle estimate sits 22.7 percentage points above what was measured; the whole stated range lies above it.
By their numbers in this assay, from the lowest: compound 3; then compounds 1 and 2 (each within the scatter of the next).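

In this assay, the change of isobutyl to sec-butyl on a saturated chain carbon bound to an amide-type nitrogen and a carbonyl carbon proves far from neutral: with the same atoms joined differently, the read-out falls by a number 26.4 percentage points lower from compound 2 to compound 3 (beyond the scatter) in a single change. With sec-butyl held in place, hydrogen in place of methyl on an aromatic carbon also matters, giving a number 19.1 percentage points lower from compound 1 to compound 3 (beyond the scatter) as its step. Compound 1 and compound 2 differ in both of these places at once, so that pair could not separate the two changes, whereas compound 3 is linked to each of them by one change and lies beyond the scatter of both. Nothing on hand accounts for either step.

The compounds shown leave open how isobutyl and the methyl behave when carried together on the shared core, as each step here was read with only one partner group. They also leave open whether a longer chain such as n-pentyl at the saturated carbon, or a methoxy or a chlorine in place of the methyl on the aromatic carbon, would follow these steps.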